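Swapping the ring on compound 1

The source may hold more compounds than are shown below. What is called first, only, known or untested is meant among the compounds shown, and "the series" means these compounds.

Compound 1 (`CCCCCCCCCCCCCCCCOP(=O)(O)OCCSC(=S)N1CCCCCC1`) has no exact number in a functional assay on MCF7 cells (Homo sapiens) for inhibition, read by MTT assay, with stated times of 18 h and 4 h; on this read-out higher numbers stand for weaker inhibition and lower numbers for stronger inhibition: compound 1 reads > 100000 nM, which is a limit. This is the limit of > 100000 nM in this assay, at which 1 of the 3 values shown sits. In this assay compound 2 (`CCCCCCCCCCOP(=O)(O)OCCSC(=S)N1CCCCCC1`) gives 43300 nM and compound 3 (`CCCCCCCCCCOP(=O)(O)OCCSC(=S)N1CCCC1`) gives 70000 nM.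

Compound 4 (`CCCCCCCCCCCCCCCCOP(=O)(O)OCCSC(=S)N1CCN(C)CC1`) keeps the chain of compound 1 and changes only the group on the thiocarbonyl carbon: 4-methylpiperazin-1-yl in place of azepan-1-yl on a thiocarbonyl carbon. Within the data shown here, two measured steps bear on this. Replacing hexyl on the chain gave an at least 2.3-fold lower number from compound 1 to compound 2 (0.36 log units; beyond the scatter), but compound 4 does not make that change. The closest comparison is a different ring swap, pyrrolidin-1-yl in place of azepan-1-yl, which gave a 1.6-fold higher number from compound 2 to compound 3 (0.21 log units; within the scatter) on the shorter chain. Among the measured compounds shown here, no compound with 4-methylpiperazin-1-yl has been measured yet, so this guide is only indirect.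

No step beyond the scatter is therefore expected in this assay, and the estimate is an at least 1.1-fold lower number from compound 1 to compound 4 (0.04 log units; that floor lies within the scatter) for this change. For compound 4 the expected value is 90000 nM, with an estimated range from 35000 nM to 200000 nM as its likely span.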

Compound 4, half-maximal inhibitory concentration: > 100000 nM
Compound 4 gave a limit, no number; the forecaster's own chance of this, stated with the estimate: 45%; middle value at least 1.1-fold (0.04 log units) away from the limit.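

Compound 1 and compound 4 each give only a limit in this assay, so no step can be read between them: the limit of > 100000 nM in this assay, at which 2 of the 4 values shown sit.

The compounds shown leave open whether 4-methylpiperazin-1-yl and azepan-1-yl on a thiocarbonyl carbon differ at all in this assay.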